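Removing a chloro from an aryl urea: an expectation

The source may hold more compounds than are shown below. What is called first, only, known or untested is meant among the compounds shown, and "the series" means these compounds.

Measured compounds in a functional assay on HCC 2998 cells (Homo sapiens) for inhibition, read by sulforhodamine B assay, with a stated time of 48 h, tested at 0.01 uM; a lower number here means a stronger effect, a higher number a weaker effect of the compound at the concentration tested:
compound 1 `O=C(Nc1cccc(-n2cc(-c3ccncc3)c(-c3cc(O)cc(Cl)c3)n2)c1)Nc1ccc(Cl)c(C(F)(F)F)c1` gives 97%
compound 2 `COc1cc(Cl)cc(-c2nn(-c3cccc(NC(=O)Nc4ccc(Cl)c(C(F)(F)F)c4)c3)cc2-c2ccncc2)c1` gives 95%
compound 3 `COc1cc(Cl)cc(-c2nn(-c3cccc(NC(=O)Nc4cc(C(F)(F)F)cc(C(F)(F)F)c4)c3)cc2-c2ccncc2)c1` gives 95%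

Compound 2 stands level with compound 3 at the digits shown, and its value is within the scatter of compound 1 as well; the one step between measured compounds, a number 2 percentage points lower from compound 1 to compound 2 (within the scatter), lies within the scatter. Compound 4 `COc1cc(Cl)cc(-c2nn(-c3cccc(NC(=O)Nc4cccc(C(F)(F)F)c4)c3)cc2-c2ccncc2)c1` differs from compound 2 in one place: hydrogen in place of chloro on an aromatic carbon. Going by the values given here, no measured step covers this change, and compound 3, which carries a different set of trifluoromethyl groups on that ring, sits at the same level as compound 2. Compound 4 is therefore expected to stay at about the same level, with an expected step of a number 1 percentage points higher from compound 2 to compound 4 (within the scatter) in this assay. The estimate for compound 4 is 96%, in a range from 86% to 104%.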

Compound 4, a percentage reported as activity, at one concentration (the size of the read-out at that concentration, not a potency): 98%
Compound 4: the middle estimate sits 2 percentage points below what was measured, within the range that was stated.
By their numbers in this assay, from the lowest: compounds 2, 3, 1 and 4 (each within the scatter of the next).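

The step of a number 3 percentage points higher from compound 2 to compound 4 (within the scatter) in this assay shows that the chloro para to a large group can give way to hydrogen with no readable effect. Hydrogen in place of trifluoromethyl gives the same picture, with a number 3 percentage points higher from compound 3 to compound 4 (within the scatter) on that ring. No measurement at hand bears on the reason for this result.

From the compounds shown here alone, whether an amine or a carboxylic acid at this position would move the number beyond the scatter stays open. So does whether these same changes would read differently at a higher tested concentration.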